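Para-substituent swap on the arylsulfonamide: chloro to methyl

This account rests on a few compounds, and the source may have more. Where it says the series, first, only, none or still open, it means among the compounds named here.

Measured so far:
- compound 1 `O=C(O)CC/C=C\CC1=CCC[C@@H]1NS(=O)(=O)c1ccc(F)cc1`: 1300 nM
- compound 2 `Cc1ccc(S(=O)(=O)N[C@H]2CCC=C2CCCCOCC(=O)O)cc1`: 1900 nM
- compound 3 `O=C(O)CC/C=C\CC1=CCC[C@@H]1NS(=O)(=O)c1ccc(Cl)cc1`: 1900 nM

In a functional assay on a cell-free system (plasma) for inhibition of thromboxane A2 receptor (Homo sapiens), read by turbidimetry (a higher number here means a weaker inhibitor, a lower number a stronger inhibitor), compound 3 gives 1900 nM, level with compound 2 at the digits shown and, together with it, the highest of the three numbers; compound 1 lies a step lower, a 1.5-fold higher number from compound 1 to compound 3 (0.16 log units; within the scatter), which is within the scatter.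

Compound 4 `Cc1ccc(S(=O)(=O)N[C@H]2CCC=C2C/C=C\CCC(=O)O)cc1` is the unmeasured member. It differs from compound 3 by methyl in place of chloro on an aromatic carbon.

Among the compounds with values here, only one measured step bears on a swap at this aromatic carbon: a 1.5-fold higher number from compound 1 to compound 3 (0.16 log units; within the scatter), within the scatter. Compound 2, which already carries the methyl on that ring but with a different chain, gives 1900 nM, the same number as compound 3. No step beyond the scatter is therefore expected for compound 4, no change at the digits printed from compound 3 to compound 4 (within the scatter).

Compound 4 is expected to give 1900 nM, within 900 nM to 4000 nM.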

Compound 4, half-maximal inhibitory concentration: 1800 nM
Beside the measured number, compound 4's estimate is 1.1-fold (0.02 log units) above it; the measured number falls inside the stated range.
By their numbers in this assay, from the lowest: compounds 1, 4, 2 and 3 (each within the scatter of the next).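

At the aromatic carbon para to a large group, with the chain held constant, methyl, chloro and fluoro give no step beyond the scatter in this assay (a 1.1-fold lower number from compound 3 to compound 4 (0.02 log units; within the scatter); a 1.4-fold higher number from compound 1 to compound 4 (0.14 log units; within the scatter)). With the methyl held constant, 4-carboxybut-1-en-1-yl in place of 3-(carboxymethoxy)propyl also stays within the scatter (a 1.1-fold lower number from compound 2 to compound 4 (0.02 log units; within the scatter)). No measurement at hand accounts for these flat steps.

On these data alone, whether an amine or a methoxy at this aromatic carbon would leave the scatter remains open. So does the effect of a longer chain on the shared core.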